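A few compounds are considered here, and "the series" means these few. Any claim that something is new, unique, unknown or untested is made for them only; others in the source may bear on it.

Measured compounds:
compound 1 `CC(C)(C)Cc1c(-c2ccccc2)sc(N)c1C(=O)c1cccc(Cl)c1`: 5%
compound 2 `CC(C)(C)Cc1c(-c2ccccc2)sc(N)c1C(=O)c1ccccc1Cl`: 1%

In an assay on CHO cells for displacement of a labelled ligand from adenosine receptor A3 (Homo sapiens), read by scintillation counting, tested at 10 uM (on this read-out higher numbers stand for more inhibition at the one concentration tested (going by the name of the read-out) and lower numbers for less inhibition), compound 1 gives 5% and compound 2 gives 1%. Compound 2 stands lowest of the two numbers, its nearest neighbour being compound 1, the step being a number 4 percentage points lower from compound 1 to compound 2 (within the scatter). Compound 3 `Cc1ccc(C(=O)c2c(N)sc(-c3ccccc3)c2CC(C)(C)C)cc1` is not yet measured; it differs from compound 2 by 4-methylphenyl in place of 2-chlorophenyl on a carbonyl carbon. For the measured compounds named here, the one step on record, a number 4 percentage points lower from compound 1 to compound 2 (within the scatter), put 2-chlorophenyl in place of 3-chlorophenyl and stayed within the scatter. No step beyond the scatter is therefore expected, an estimated a number 3 percentage points higher from compound 2 to compound 3 (within the scatter). Compound 3 is estimated at 4%, between -10% and 18%.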

Compound 3, a percentage reported as inhibition, at one concentration (the size of the read-out at that concentration, not a potency): 1%
For compound 3 the middle estimate is 3 percentage points above the measured one; low and high end bracket the measured number.
By their numbers in this assay, from the lowest: compounds 2, 3 and 1 (each within the scatter of the next).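

With 4-methylphenyl in place of 2-chlorophenyl on a carbonyl carbon, this assay gives no change at the digits printed from compound 2 to compound 3 (within the scatter) and, with 4-methylphenyl in place of 3-chlorophenyl, a number 4 percentage points lower from compound 1 to compound 3 (within the scatter) as well. A substituent of carbon only thus reads here the same as the two chlorine-bearing ones, so swapping chlorine for methyl along with its ring position moves nothing beyond the scatter. Nothing measured here offers an explanation for this. The compounds shown leave open whether an amine or a carboxylic acid on this phenyl ring would give a number beyond the scatter.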